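A few compounds are considered here, and "the series" means these few. Any claim that something is new, unique, unknown or untested is made for them only; others in the source may bear on it.

Compound 2 `O=C(CCl)Nc1cccc(-c2nc3ccccc3s2)c1` stands lowest of the two numbers recorded in an ADME assay for permeability, using PAMPA (on this read-out higher numbers stand for higher permeability and lower numbers for lower permeability), giving 660 10^-6 cm/s. Its nearest neighbour is compound 1 `C=CC(=O)Nc1cccc(-c2nc3ccccc3s2)c1`, which in this assay gives 797 10^-6 cm/s, and the step of a 1.2-fold lower number from compound 1 to compound 2 (0.08 log units; within the scatter) lies within the scatter. Compound 3 `O=C(Nc1cccc(-c2nc3ccccc3s2)c1)c1cnccc1Cl` differs from compound 2 by 4-chloropyridin-3-yl in place of chloromethyl on a carbonyl carbon. Within the data shown here, only one measured step exists, a 1.2-fold lower number from compound 1 to compound 2 (0.08 log units; within the scatter), and it concerns a smaller exchange at the same carbonyl carbon; no measured step introduces an aromatic ring there, so the guidance is thin. Given that the step of a 1.2-fold lower number from compound 1 to compound 2 (0.08 log units; within the scatter) stayed within the scatter, compound 3 is expected to show a step of a 1.3-fold lower number from compound 2 to compound 3 (0.12 log units; within the scatter), modest and downward rather than none at all. Compound 3 is therefore estimated at 500 10^-6 cm/s in this assay, within a range from 250 10^-6 cm/s to 800 10^-6 cm/s.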

Compound 3, apparent permeability: 732 10^-6 cm/s
Estimate against measurement, compound 3: 1.5-fold (0.17 log units) below, within the range that was stated.
By their numbers in this assay, from the lowest: compounds 2, 3 and 1 (each within the scatter of the next).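

In this assay, 4-chloropyridin-3-yl in place of chloromethyl on a carbonyl carbon gives a 1.1-fold higher number from compound 2 to compound 3 (0.04 log units; within the scatter), and the same group in place of vinyl gives a 1.1-fold lower number from compound 1 to compound 3 (0.04 log units; within the scatter). The position, a carbonyl carbon whose other neighbour is an amide-type nitrogen, therefore takes a six-membered aromatic ring with 7 heavy atoms with no step beyond the scatter, whereas the earlier step covered only an exchange of chloromethyl for vinyl. Nothing measured here accounts for this result. The compounds shown leave open whether an amine, a carboxylic acid or a longer chain on this carbonyl carbon would also fall within the scatter of these three compounds. They also leave open whether a pyridine ring without its chlorine would do so, and whether any group at this place produces a step beyond the scatter.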